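The source may hold more compounds than are shown below. What is called first, only, known or untested is meant among the compounds shown, and "the series" means these compounds.

Measured in a functional assay on A-375 cells (Homo sapiens) for antiproliferative activity, read by MTT assay, with a stated time of 24 h; a higher number here means a weaker inhibitor, a lower number a stronger inhibitor:

Compound 1 `COc1cc(OC)c(-c2coc3cc(OCc4ccccc4F)ccc3c2=O)cc1OC`: 2100 nM
Compound 2 `COc1cc(OC)c(-c2coc3cc(OCc4ccc(Br)cc4)ccc3c2=O)cc1OC`: 1000 nM
Compound 3 `COc1cc(OC)c(-c2coc3cc(OCc4ccc([N+](=O)[O-])cc4)ccc3c2=O)cc1OC`: > 10000 nM

Compound 3 stands at the limit of > 10000 nM in this assay, at which 1 of the 3 values shown sits; this is a limit of the assay and not a number. The next compound, compound 4 `COc1cc(OC)c(-c2coc3cc(OCc4ccc(Cl)cc4)ccc3c2=O)cc1OC`, has not yet been measured. It departs from compound 3 by one exchange: chloro in place of nitro on an aromatic carbon. In words, chloro takes the place of nitro on an aromatic carbon, turning the 4-nitrobenzyl group into a 4-chlorobenzyl group.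

Two measured steps lead into the nitro compound. The closest is an at least 10-fold higher number from compound 2 to compound 3 (1.00 log units; beyond the scatter), which puts nitro in place of bromo on an aromatic carbon. The other is an at least 4.7-fold higher number from compound 1 to compound 3 (0.67 log units; beyond the scatter). The remaining step, a 2.1-fold lower number from compound 1 to compound 2 (0.32 log units; beyond the scatter), is modest. Both steps into the nitro compound raise the number, so removing nitro is expected to lower it in this assay. An estimated step of an at least 7.6-fold lower number from compound 3 to compound 4 (0.88 log units; beyond the scatter) is expected, its true size left open by the limit. Compound 4 is estimated at 1300 nM, with an expected range of 450 nM to 4000 nM.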

Compound 4, half-maximal inhibitory concentration: 1020 nM
For compound 4 the middle estimate is 1.3-fold (0.11 log units) above the measured one; measured number inside the range.
By their numbers in this assay, from the lowest: compounds 2 and 4 (each within the scatter of the next); then compound 1. At a limit, above all of these: compound 3.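

In this assay, the exchange of the 4-nitrobenzyl group for the 4-chlorobenzyl group gives an at least 9.8-fold lower number from compound 3 to compound 4 (0.99 log units; beyond the scatter), showing that the weak result of compound 3 does not extend to every group at this place, para to a large group. Chloro and bromo at this place cannot be told apart, with a 1.0-fold higher number from compound 2 to compound 4 (0.01 log units; within the scatter), so among the para groups shown, only nitro stands apart. The 4-chlorophenyl group also matches the 4-bromophenyl group in its relation to the 2-fluorophenyl group, with a 2.1-fold lower number from compound 1 to compound 4 (0.31 log units; beyond the scatter).

The true size of the step from nitro to chloro stays open, as compound 3 stands at a limit and not a number: the limit of > 10000 nM in this assay, at which 1 of the 4 values shown sits. The compounds shown also leave open how an amine, a carboxylic acid or a methoxy group at this place would read.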